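Removing a methyl from an aryl ether in a glycoside series

This account rests on a few compounds, and the source may have more. Where it says the series, first, only, none or still open, it means among the compounds named here.

Compound 1, `C/C=C1/[C@H](O[C@@H]2O[C@H](CO)[C@@H](O)[C@H](O)[C@H]2O)OC=C(C(=O)OC)[C@H]1CC(=O)OCc1ccc2c(c1)OCCO2`, in a functional assay on SK-BR-3 cells (Homo sapiens) for antiproliferative activity, read by MTT assay, with a stated time of 72 h (a higher number here means a weaker inhibitor, a lower number a stronger inhibitor), gives only a limit, > 15000 nM.
Compound 2, `C/C=C1/[C@H](O[C@@H]2O[C@H](CO)[C@@H](O)[C@H](O)[C@H]2O)OC=C(C(=O)OC)[C@H]1CC(=O)OCCC`, in this assay gives only a limit, > 15000 nM.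
Compound 3, `C/C=C1/[C@H](O[C@@H]2O[C@H](CO)[C@@H](O)[C@H](O)[C@H]2O)OC=C(C(=O)OC)[C@H]1CC(=O)OCCc1ccc(OC)cc1`, in this assay gives only a limit, > 20000 nM.

For the measured compounds named here, every value so far is a limit rather than a number, so compound 3 stands nowhere in particular among its neighbours: it sits at the limit of > 20000 nM in this assay, at which 1 of the 3 values shown sits, while the other two sit at the limit of > 15000 nM in this assay, at which 2 of the 3 values shown sit. The three connecting steps, a step that the two limits leave unreadable from compound 1 to compound 2, a step that the two limits leave unreadable from compound 1 to compound 3 and a step that the two limits leave unreadable from compound 2 to compound 3, are each unreadable because both ends are limits. Compound 4, `C/C=C1/[C@H](O[C@@H]2O[C@H](CO)[C@@H](O)[C@H](O)[C@H]2O)OC=C(C(=O)OC)[C@H]1CC(=O)OCCc1ccc(O)cc1`, is related to compound 3 by a single change: hydrogen in place of methyl on an oxygen on an aromatic ring. Going by the values given here, none of the measured steps touches this position, and none gives a readable size, so no direction can be drawn from them for this assay. Given that compound 3 returns only > 20000 nM, compound 4 is expected to stay in the same region, at an estimated 30000 nM with a range from 10000 nM to 100000 nM. That estimate implies a step that the limit leaves unreadable from compound 3 to compound 4 from compound 3 to compound 4, most likely again reported as a limit.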

Compound 4, half-maximal inhibitory concentration: > 20000 nM
Compound 4 was reported as a limit (the forecaster's own chance of this, stated with the estimate: 85%); the middle value does not contradict the limit.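

In this assay compound 4 gives only a limit, > 20000 nM. For the compounds shown here, compound 1, compound 2 and compound 3 also give only limits, so no step to compound 4 can be read. Whether methoxy to hydroxy, or any other change among these four compounds, alters antiproliferative activity remains open.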